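Amide-to-acid step on a shared nitrile core

The source may report more compounds than this note shows. Statements on the series, on what has been measured and on what is new or still open speak of the compounds shown alone.

Measured so far, in a physicochemical assay for lipophilicity, read by HPLC, at pH 7.5; a lower number here means a more polar compound, a higher number a more lipophilic compound:
compound 1 `CC[C@@H](Nc1c(C#N)c(-c2ccc(Br)cc2)nc2cnccc12)C(=O)O` gives 1.6
compound 2 `CCOc1ccccc1-c1ccc(-c2nc3cnccc3c(N[C@H](CC)C(N)=O)c2C#N)cc1` gives 3
compound 3 `CC[C@@H](Nc1c(C#N)c(-c2ccc(Br)cc2)nc2cnccc12)C(N)=O` gives 2.2

Compound 2 stands highest of the three in this assay; its nearest neighbour is compound 3, and compound 1 lies furthest from it. The two cores differ in one place, (2-ethoxyphenyl in place of bromo on an aromatic carbon), and that change gave a number 0.80 log units lower from compound 2 to compound 3 (beyond the scatter).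

The change under consideration here, (hydroxy in place of amino on a carbonyl carbon), has been measured once, giving a number 0.60 log units lower from compound 3 to compound 1 (beyond the scatter). Compound 4 `CCOc1ccccc1-c1ccc(-c2nc3cnccc3c(N[C@H](CC)C(=O)O)c2C#N)cc1` is not yet measured. It stands to compound 2 as compound 1 stands to compound 3: the difference, (hydroxy in place of amino on a carbonyl carbon), is the same change, at the same place on a carbonyl carbon whose other neighbour is a saturated chain carbon.

With a single prior example, the step from compound 2 to compound 4 in this assay is expected to be about the same size as the earlier one, a number 0.60 log units lower from compound 2 to compound 4 (beyond the scatter), resting on a number 0.60 log units lower from compound 3 to compound 1 (beyond the scatter). Compound 4 is therefore estimated at 2.4, with a likely range from 2 to 2.8.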

Compound 4, distribution coefficient: 2.1
Estimate against measurement, compound 4: 0.30 log units above, within the range that was stated.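

In this assay the exchange of carbamoyl for carboxy runs the same way on both cores, with a number 0.90 log units lower from compound 2 to compound 4 (beyond the scatter) on the 2-ethoxyphenyl core and a number 0.60 log units lower from compound 3 to compound 1 (beyond the scatter) on the bromo core, each beyond the scatter. The other side of the square agrees in direction, with a number 0.50 log units higher from compound 1 to compound 4 (beyond the scatter) for the acids and a number 0.80 log units lower from compound 2 to compound 3 (beyond the scatter) for the amides. These two pairs show the direction carrying over between these two cores, but they do not establish a fixed step size or any transfer to another core, and nothing measured here accounts for the result.

The compounds shown leave open whether a methyl ester or a primary amine in place of the carboxy group would follow the same pattern on either core. They also leave open whether the step holds with a longer chain in place of the 1-carboxypropyl group, or with a methoxy or a chloro group in place of bromo.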